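A few compounds are considered here, and "the series" means these few. Any claim that something is new, unique, unknown or untested is made for them only; others in the source may bear on it.

Compound 1 `COc1cc(CNc2nc3cc(N)cc(N)c3nc2-c2ccccc2)cc(OC)c1OC`: in a functional assay on SK-MEL-5 cells (Homo sapiens) for inhibition, read by sulforhodamine B assay, with a stated time of 48 h (a higher number here means that more compound is tolerated, a lower number that less compound is tolerated), compound 1 gives 29500 nM.
Compound 2 `COc1ccc(CNc2nc3cc(N)cc(N)c3nc2-c2ccccc2)cc1OC`: in this assay compound 2 gives 77600 nM.
Compound 3 `CCOC(=O)[C@H](CCC(=O)O)NC(=O)c1ccc(CNc2nc3cc(N)cc(N)c3nc2-c2ccccc2)cc1`: in this assay compound 3 gives a limit of the assay rather than a number, < 100000 nM.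

Among the two numbers on hand, compound 2 stands highest; its nearest neighbour is compound 1, and the step between them is a 2.6-fold higher number from compound 1 to compound 2 (0.42 log units; beyond the scatter). The result for compound 3 is a limit and not a number (the limit of < 100000 nM in this assay, at which 1 of the 3 values shown sits).

Compound 4 `COc1ccc(CNc2nc3cc(N)cc(N)c3nc2-c2ccccc2)cc1` has not yet been measured. It differs from compound 2 in one place: hydrogen in place of methoxy on an aromatic carbon. Going by the values given here, the only measured step that bears on this change is a 2.6-fold higher number from compound 1 to compound 2 (0.42 log units; beyond the scatter), which is itself a hydrogen in place of methoxy on an aromatic carbon; that step was modest, beyond the scatter, and raised the number. Compound 4 is therefore expected to show a step of a 1.5-fold higher number from compound 2 to compound 4 (0.19 log units; within the scatter) in this assay, a modest rise, with a real chance that the assay reports only a limit. Compound 4 is estimated at 120000 nM in this assay, in a range from 55000 nM to 260000 nM.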

Compound 4, concentration lethal to 50% of the cells: 56200 nM
Compound 4: the middle estimate sits 2.1-fold (0.33 log units) above what was measured; measured number inside the range.
By their numbers in this assay, from the lowest: compounds 1, 4 and 2 (each within the scatter of the next, the first and the last beyond it).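

Taking one more methoxy off the ring, going from 3,4-dimethoxyphenyl to 4-methoxyphenyl, gives a 1.4-fold lower number from compound 2 to compound 4 (0.14 log units; within the scatter) and so leaves no difference that can be told apart from the ordinary spread of repeat measurements. The earlier step of the same kind, a 2.6-fold higher number from compound 1 to compound 2 (0.42 log units; beyond the scatter) and so a real one, therefore does not carry over: hydrogen in place of methoxy has no single size across these compounds, and its effect depends on where on the ring it happens. Nothing in the data explains why the two steps differ.

As far as these compounds go, what a hydroxyl, a chlorine or a longer chain such as ethoxy would do at this position remains open. So does the result for a plain phenyl ring carrying no methoxy at all.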